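The compounds below may be only part of what the source reports. "The series", "measured", "known", "first", "only" and "open" are said of these compounds alone.

Measured so far in this series:
compound 1 `Cc1ccc(NC(=O)CSc2snnc2-c2ccc(Br)cc2Br)c([N+](=O)[O-])c1` – > 229000 nM
compound 2 `CC(=O)c1ccc(NC(=O)CSc2snnc2-c2ccc(Br)cc2Br)c(Br)c1` – > 206000 nM
compound 3 `Cc1ccc2sc(NC(=O)CSc3snnc3-c3ccc(Br)cc3Br)nc2c1` – 23600 nM

In an ADME assay on MT4 cells (Homo sapiens) for cytotoxicity, read by MTT assay, with a stated time of 5 days (a lower number here means that less compound is tolerated, a higher number that more compound is tolerated), compound 2 gives only a limit, > 206000 nM, and no number is known for it. Compound 1 likewise reaches only a limit, > 229000 nM. Among the measured compounds shown here, compound 3 is the one compound here with a measured number, 23600 nM. The two limits stand as the limit of > 206000 nM in this assay, at which 1 of the 3 values shown sits, and (the limit of > 229000 nM in this assay, at which 1 of the 3 values shown sits). Compound 4 `O=C(CSc1snnc1-c1ccc(Br)cc1Br)Nc1ccccc1Br` is not yet measured; it differs from compound 2 by hydrogen in place of acetyl on an aromatic carbon. For the measured compounds named here, no step between measured compounds is available to size this change, so a step of no more than the usual scatter is expected, in no particular direction. Compound 4 is therefore estimated at 200000 nM, with a range of 60000 nM to 400000 nM. The expected step is an at least 1.0-fold lower number from compound 2 to compound 4 (0.01 log units; that floor lies within the scatter), most likely ending again at a limit.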

Compound 4, half-maximal cytotoxic concentration: > 221000 nM
Compound 4 gave a limit, no number (the forecaster's own chance of this, stated with the estimate: 70%); middle value at least 1.1-fold (0.04 log units) away from the limit.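

Compound 2 gives > 206000 nM as a limit. Among the compounds shown here, compound 4 gives > 221000 nM as a limit too, so no step between these two compounds can be read. On these data alone, whether hydrogen in place of acetyl on an aromatic carbon changes the read-out at all remains open.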